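Aryl amine swap on the lactone core

The source may hold more compounds than are shown below. What is called first, only, known or untested is meant among the compounds shown, and "the series" means these compounds.

Of the compounds shown here, two have been measured in a functional assay on A549 cells (Homo sapiens) for cytotoxicity, read by sulforhodamine B assay; a higher number here means a weaker inhibitor, a lower number a stronger inhibitor. Compound 1 `C=C1[C@@H](C/C=C2/C(=O)OC[C@H]2OC(C)=O)[C@]2(C)CC[C@@H](OC(C)=O)[C@@](C)(CO[Si](C)(C)C(C)(C)C)[C@H]2C[C@@H]1O` gives 6850 nM in this assay. Compound 2 `C=C1[C@@H](OC(C)=O)C[C@@H]2[C@](C)(COC=O)[C@H](OC(C)=O)CC[C@@]2(C)[C@@H]1C[C@@H](Nc1ccc(OC)c(OC)c1)C1=CCOC1=O` carries a (3,4-dimethoxyphenyl)amino group on a saturated chain carbon; in this assay compound 2 gives only a limit, > 50000 nM, and no number. That places compound 2 at the limit of > 50000 nM in this assay, at which 1 of the 2 values shown sits. Compounds 1 and 2 differ in more than one place, so their two values stand side by side without a step between them.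

Compound 3 `C=C1[C@@H](OC(C)=O)C[C@@H]2[C@](C)(COC=O)[C@H](OC(C)=O)CC[C@@]2(C)[C@@H]1C[C@@H](Nc1ccc(F)cc1)C1=CCOC1=O` differs from compound 2 in one place: 4-fluorophenyl in place of 3,4-dimethoxyphenyl on an amine nitrogen. The amine nitrogen and its saturated chain carbon neighbour are kept.

For the measured compounds named here, no measured step in this assay bears on this change, and compound 2 offers only a limit to start from. The expected step of an at least 1.1-fold lower number from compound 2 to compound 3 (0.04 log units; that floor lies within the scatter) is therefore small, with no direction asserted beyond the scatter, and compound 3 is expected to stay near the limit of this assay. Compound 3 is estimated at 45000 nM, within a range from 10000 nM to 200000 nM, with a fair chance that this assay again reports only a limit.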

Compound 3, half-maximal inhibitory concentration: 21300 nM
Beside the measured number, compound 3's estimate is 2.1-fold (0.32 log units) above it; measured number inside the range.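

In this assay, for the compounds shown here, 4-fluorophenyl in place of 3,4-dimethoxyphenyl on the amine nitrogen gives an at least 2.3-fold lower number from compound 2 to compound 3 (0.37 log units; beyond the scatter), the first measured step. With the amine nitrogen and its saturated chain carbon kept, the read-out therefore responds to the aryl group at this position, and compound 3 gives 21300 nM, a number where compound 2 offers none. The step is only a floor and its full size is unknown, as compound 2 stands at a limit: the limit of > 50000 nM in this assay, at which 1 of the 3 values shown sits.

The compounds shown leave open whether the step follows the departure of the two methoxy groups or the arrival of the fluorine, as this single swap changes both at once. Also open, as far as these compounds go, is how an unsubstituted phenyl, a 4-methoxyphenyl or a 4-chlorophenyl on the same amine nitrogen would read in this assay, which would begin to separate those two contributions.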